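The source may hold more compounds than are shown below. What is called first, only, known or untested is meant among the compounds shown, and "the series" means these compounds.

Measured so far:
compound 1, `Cc1ccoc1C(=O)Nc1c(F)cc(N2C(=O)C3=C(CCCC3)C2=O)c(F)c1F`: in a functional assay for positive allosteric modulation of metabotropic glutamate receptor 1 (Homo sapiens), read by calcium flux, in the presence of a further agent that is not named here (on this read-out lower numbers stand for an effect already at smaller amounts and higher numbers for an effect only at larger amounts of compound), compound 1 gives > 10000 nM, which is a limit of the assay and not a number.
compound 2, `Cc1cc(N2C(=O)C3=C(CCCC3)C2=O)c(F)cc1NC(=O)c1ccco1`: in this assay compound 2 gives > 10000 nM, again a limit of the assay and not a number.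

Compound 2 therefore stands nowhere in particular on the numbers shown: its own result is a limit, and the one other value shown is a limit too, both sitting at the limit of > 10000 nM in this assay, at which 2 of the 2 values shown sit. Among the compounds with values here, no step between two measured compounds can be computed from this pair, so nothing is known here about how any change in the shared core or its substituents shifts the read-out.

Compound 3, `Cc1nc(C(=O)Nc2cc(F)c(N3C(=O)C4=C(CCCC4)C3=O)cc2C)cs1`, is yet to be measured in this assay. It differs from compound 2 in one place, (2-methyl-1,3-thiazol-4-yl in place of furan-2-yl on a carbonyl carbon), with the carbonyl carbon and the amide-type nitrogen kept.

With both measured values at the limit, the expected step from compound 2 to compound 3 is set at a step that the limit leaves unreadable from compound 2 to compound 3, with no direction that the data can support. Compound 3 is estimated at 15000 nM, between 3000 nM and 60000 nM, and it is expected that the assay most likely again reports only a limit.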

Compound 3, half-maximal effective concentration: > 10000 nM
Compound 3: a limit, no number; the forecaster's own chance of this, stated with the estimate: 70%; the middle value lies beyond the limit too.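

No step can be read from compound 2 to compound 3, as both results are limits and not numbers, so the swap of furan-2-yl for 2-methyl-1,3-thiazol-4-yl on the carbonyl carbon stays unsized. Within the data shown here, the series so far sits at one value: the limit of > 10000 nM in this assay, at which 3 of the 3 values shown sit. The compounds shown leave open whether any change to the shared core or its substituents gives a readable number.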